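Removing the chloro from compound 2

The source may hold more compounds than are shown below. What is called first, only, known or untested is meant among the compounds shown, and "the series" means these compounds.

Values in a functional assay on MOLM-13 cells (Homo sapiens) for inhibition, read by MTT assay, with a stated time of 24 h (a lower number here means a stronger inhibitor, a higher number a weaker inhibitor), so far
- compound 1 `O=[N+]([O-])c1cc(Cl)ccc1CNc1cc(C(F)(F)F)cc2[nH]ncc12` gives 4130 nM
- compound 2 `O=[N+]([O-])c1ccc(Cl)cc1CNc1cc(C(F)(F)F)cc2[nH]ncc12` gives 1050 nM

Compound 2 has the lower of the two numbers, and its gap to compound 1 lies beyond the scatter. Compound 3 `O=[N+]([O-])c1ccccc1CNc1cc(C(F)(F)F)cc2[nH]ncc12` differs from compound 2 by hydrogen in place of chloro on an aromatic carbon. Going by the values given here, no measured pair isolates this change, and compound 1 at 4130 nM shows that carrying a chloro does not alone give the lower number. A modest step toward a higher number is expected in this assay, possibly not beyond the scatter. The expected size is a 1.9-fold higher number from compound 2 to compound 3 (0.28 log units; within the scatter) on this estimate. For compound 3 the estimated value is 2000 nM, within an expected range of 700 nM to 6000 nM here.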

Compound 3, half-maximal inhibitory concentration: 2350 nM
The estimate for compound 3 lay 1.2-fold (0.07 log units) below the measured number; low and high end bracket the measured number.
By their numbers in this assay, from the lowest: compound 2; then compounds 3 and 1 (each within the scatter of the next).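

In this assay, hydrogen in place of the chloro para to a nitro group gives a modest step beyond the scatter (a 2.2-fold higher number from compound 2 to compound 3 (0.35 log units; beyond the scatter)), so the chloro of compound 2 has a readable effect at this place. The same exchange on compound 1 stays within the scatter (a 1.8-fold lower number from compound 1 to compound 3 (0.24 log units; within the scatter)), so the effect of this change depends on where the chloro stands. No measurement here explains the difference.

As far as these compounds go, whether a fluoro, methyl or methoxy group at this place would match the chloro remains open. So does whether an amine could replace the nitro group.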